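Swapping 4-chlorophenyl for thiophen-2-yl on a shared core

A few compounds are considered here, and "the series" means these few. Any claim that something is new, unique, unknown or untested is made for them only; others in the source may bear on it.

Measured in a functional assay on L1210 cells (Mus musculus) for antiproliferative activity, with a stated time of 48 h; a lower number here means a stronger inhibitor, a higher number a weaker inhibitor
Compound 1 (`C=C(Br)C(=O)Nc1ccc(/C=C/C(=O)c2ccc(Cl)cc2)cc1`) gives 1100 nM
Compound 2 (`C=C(Br)C(=O)Nc1ccc(/C=C/C(=O)c2cccc3ccccc23)cc1`) gives 1100 nM

Compound 1 stands level with compound 2 at the digits shown, and the two values lie within the usual scatter of repeated measurements. For the measured compounds named here, the next compound to consider, compound 3 (`C=C(Br)C(=O)Nc1ccc(/C=C/C(=O)c2cccs2)cc1`), has no measurement yet. It carries thiophen-2-yl in place of 4-chlorophenyl on a carbonyl carbon.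

Going by the values given here, no measured step between single-place relatives is available to guide a forecast, so the evidence is thin. Among the compounds with values here, the only anchors are compound 1 (1100 nM) and compound 2 (1100 nM), which show the same value. On that basis, no step beyond the scatter is expected in this assay, and no direction is favoured with any confidence. The expected change is a 1.1-fold higher number from compound 1 to compound 3 (0.04 log units; within the scatter), a small one. For compound 3 the estimated value is 1200 nM, with an expected range from 500 nM to 3000 nM.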

Compound 3, half-maximal inhibitory concentration: 250 nM
Estimate against measurement, compound 3: 4.8-fold (0.68 log units) above; measured number below the stated range.
By their numbers in this assay, from the lowest: compound 3; then compounds 1 and 2 (each within the scatter of the next).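

In this assay, the group on the carbonyl carbon proves able to move the number: thiophen-2-yl in place of 4-chlorophenyl gives a 4.4-fold lower number from compound 1 to compound 3 (0.64 log units; beyond the scatter) and so a step beyond the scatter. Compound 1 and compound 2 share one printed value, which gave no sign of such a shift at this place. The new result shows that this place is not indifferent to the group it carries, and that a five-membered aromatic ring with one sulfur is tolerated there. Nothing available explains the lower number.

The compounds shown leave open whether the sulfur or the five-membered ring goes with the lower number. A furan-2-yl group, with oxygen in the ring, or a plain phenyl group would help to separate the two.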